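This account rests on a few compounds, and the source may have more. Where it says the series, first, only, none or still open, it means among the compounds named here.

Measured so far in a physicochemical assay for solubility, read by LC-MS, in phosphate buffer, measured as kinetic solubility, with a stated time of 24 h, at 25 degrees C, at pH 7.4; a lower number here means a less soluble compound, a higher number a more soluble compound:
- compound 1 `Nc1cc(-c2ccc3c(N)n[nH]c3c2)nc(N)n1`, giving 58000 nM
- compound 2 `Nc1nccc(-c2cc(OCc3ccccc3)c3c(N)n[nH]c3c2)n1`, giving 85000 nM

Within the data shown here, only two compounds have been measured, and no pair among them differs in a single place. The numbers for compound 2 and compound 1 sit within the usual scatter of each other in this assay, so the two cannot be told apart on solubility; neither one can be called the more soluble.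

Compound 3 `Nc1nccc(-c2cc(Oc3ccccc3)c3c(N)n[nH]c3c2)n1` is not yet measured. It differs from compound 2 in one place: phenyl in place of benzyl on an oxygen on an aromatic ring. Among the measured compounds shown here, both groups carry the same count of donors and acceptors and no charge, and the data hold no step of this kind to lean on. The change from compound 2 to compound 3 is therefore expected to bring no step beyond the scatter in this assay, in either direction, as a 1.1-fold lower number from compound 2 to compound 3 (0.03 log units; within the scatter). Compound 3 is expected to give about 80000 nM, within a range from 40000 nM to 160000 nM.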

Compound 3, solubility: 117000 nM
For compound 3 the middle estimate is 1.5-fold (0.17 log units) below the measured one; the measured number falls inside the stated range.
By their numbers in this assay, from the lowest: compounds 1, 2 and 3 (each within the scatter of the next).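

Among these compounds, the swap from benzyloxy to phenoxy is the first comparison in this set that changes a single place, and in this assay it reads as a 1.4-fold higher number from compound 2 to compound 3 (0.14 log units; within the scatter) on the solubility scale. On this oxygen, then, benzyl and phenyl cannot be told apart by this measurement, and neither group can be called the better one for solubility. Nothing measured here offers an explanation for this result.

Both groups shown on this oxygen are rings of carbon only, so what an amine, a carboxylic acid or a longer chain would do at this place stays open. Among the compounds shown here, it also stays open whether the same swap would give a similar step on a different core, since only one such pair is available.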